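The compounds below may be only part of what the source reports. "The series", "measured", "known", "first", "only" and "open" are said of these compounds alone.

compound 1 `Cc1cc(C)cc(S(=O)(=O)c2c(C(=O)N[C@@H]3CCN(Cc4cccnc4)C3)[nH]c3ccc(Cl)cc23)c1`: 36500 nM
compound 2 `Cc1cc(C)cc(S(=O)(=O)c2c(C(=O)N[C@@H]3CCN(CC(N)=O)C3)[nH]c3ccc(Cl)cc23)c1`: 31000 nM
compound 3 `Cc1cc(C)cc(S(=O)(=O)c2c(C(=O)N[C@H]3CCN(Cc4ccccc4F)C3)[nH]c3ccc(Cl)cc23)c1`: 215000 nM

In an ADME assay on MT4 cells (Homo sapiens) for cytotoxicity, read by MTT assay, with a stated time of 5 days (a higher number here means that more compound is tolerated, a lower number that less compound is tolerated), compound 1 stands within the scatter of compound 2, and both read well short of compound 3. The unmeasured compound 4 `Cc1cc(C)cc(S(=O)(=O)c2c(C(=O)N[C@H]3CCN(CC(N)=O)C3)[nH]c3ccc(Cl)cc23)c1` differs from compound 1 as follows: 1-(carbamoylmethyl)pyrrolidin-3-yl in place of 1-((pyridin-3-yl)methyl)pyrrolidin-3-yl on an amide-type nitrogen. Among the measured compounds shown here, one measured step bears on this, carbamoyl in place of pyridin-3-yl, a 1.2-fold lower number from compound 1 to compound 2 (0.07 log units; within the scatter). However, the stereocentre of compound 4 matches that of compound 3, not compound 2, and no measured step isolates that difference. No change beyond the scatter is therefore expected in this assay. The estimated step is a 1.2-fold higher number from compound 1 to compound 4 (0.06 log units; within the scatter). For compound 4 the expected value is 42000 nM, with an estimated range of 18000 nM to 120000 nM.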

Compound 4, half-maximal cytotoxic concentration: 28100 nM
Estimate against measurement, compound 4: 1.5-fold (0.17 log units) above; the measured number falls inside the stated range.
By their numbers in this assay, from the lowest: compounds 4, 2 and 1 (each within the scatter of the next); then compound 3.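

In this assay, the configuration of 1-(carbamoylmethyl)pyrrolidin-3-yl on the amide-type nitrogen makes no difference beyond the scatter (a 1.1-fold lower number from compound 2 to compound 4 (0.04 log units; within the scatter)). This reading isolates the stereocentre, and it rests on one point: the fact that compounds 2 and 4 differ only in the configuration as drawn. With the configuration held, carbamoyl in place of 2-fluorophenyl gives a step beyond the scatter (a 7.7-fold lower number from compound 3 to compound 4 (0.88 log units; beyond the scatter)), whereas the exchange from compound 1 stays within it (a 1.3-fold lower number from compound 1 to compound 4 (0.11 log units; within the scatter)). The compounds shown leave open whether a primary amine or a carboxylic acid on that chain carbon would read the same. They also leave open whether the number of compound 3 holds for its other configuration.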